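A few compounds are considered here, and "the series" means these few. Any claim that something is new, unique, unknown or untested is made for them only; others in the source may bear on it.

In a functional assay on HepG2 cells (Homo sapiens) for antiproliferative activity, read by MTT assay, with a stated time of 48 h (on this read-out higher numbers stand for weaker inhibition and lower numbers for stronger inhibition), compound 1 `COc1ccc(/C=C/c2cc(OC)cc(OC)c2/C=C/C(=O)c2cccc(OC)c2)cc1` gives 11.6 ug/mL and compound 2 `COc1ccc(/C=C/c2cc(OC)cc(OC)c2/C=C/C(=O)c2ccc(N)cc2)cc1` gives 7.5 ug/mL. Among the measured compounds shown here, these two values lie within the scatter of each other, so compound 2 does not stand apart on the numbers so far. Compound 3 `COc1ccc(/C=C/c2cc(OC)cc(OC)c2/C=C/C(=O)c2ccc(C)c(C)c2)cc1` shares their core, and its difference from compound 2 is 3,4-dimethylphenyl in place of 4-aminophenyl on a carbonyl carbon. For the measured compounds named here, only one measured step bears on this change: a 1.5-fold lower number from compound 1 to compound 2 (0.19 log units; within the scatter). That step also exchanged the group on a carbonyl carbon, and it stayed within the scatter. Going by the values given here, no measured compound carries the 3,4-dimethylphenyl group, so the evidence is indirect, and no shift beyond the scatter is expected in this assay. The estimate amounts to a 1.2-fold higher number from compound 2 to compound 3 (0.08 log units; within the scatter), which is expected to be no real change. For compound 3 the expected value is 9 ug/mL, with an estimated range of 4 ug/mL to 20 ug/mL.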

Compound 3, half-maximal inhibitory concentration: 0.2 ug/mL
Beside the measured number, compound 3's estimate is 45-fold (1.65 log units) above it; measured number below the stated range.
By their numbers in this assay, from the lowest: compound 3; then compounds 2 and 1 (each within the scatter of the next).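

In this assay, the group on the carbonyl carbon proves able to move the number far more than the earlier exchange suggested: that exchange gave only a 1.5-fold lower number from compound 1 to compound 2 (0.19 log units; within the scatter), whereas 3,4-dimethylphenyl gives a 38-fold lower number from compound 2 to compound 3 (1.57 log units; beyond the scatter) and a 58-fold lower number from compound 1 to compound 3 (1.76 log units; beyond the scatter). With both steps beyond the scatter, compound 3 is the most potent of the three, so the shift is not tied to which of the two earlier groups it replaces. Nothing available here accounts for the size of this shift.

The compounds shown leave open whether both methyl groups are needed, or whether a phenyl ring with a single methyl group, with chlorine in place of methyl, or with no substituent at all would give a similar number. They also leave open whether longer chains such as ethyl on the ring would keep this gain.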